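The compounds below may be only part of what the source reports. "The series", "measured", "known", "first", "only" and "open" are said of these compounds alone.

Three compounds share one core and differ only in the chain attached to the far aromatic ring. Compound 1 `CCCCCCC#Cc1ccc(S(=O)(=O)Nc2cccc(-c3csc(NC(C)=O)n3)c2)cc1` carries a shorter chain ending in a triple bond, and in a functional assay on A-375 cells (Homo sapiens) for antiproliferative activity, read by trypan blue exclusion, with a stated time of 48 h, tested at 1 uM (on this read-out lower numbers stand for a stronger effect and higher numbers for a weaker effect at the one concentration tested), compound 1 gives 40.7%. Compound 2 `CCCCCCCCC#Cc1ccc(S(=O)(=O)Nc2cccc(-c3csc(NC(C)=O)n3)c2)cc1` has a longer chain of the same kind, and in this assay compound 2 gives 39.6%. Compound 3 `CCCCCCCCc1ccc(S(=O)(=O)Nc2cccc(-c3csc(NC(C)=O)n3)c2)cc1` carries a fully saturated chain, and in this assay compound 3 gives 34.8%. All three numbers sit close together: a number 1.1 percentage points higher from compound 2 to compound 1 (within the scatter), a number 5.9 percentage points lower from compound 1 to compound 3 (within the scatter), and a number 4.8 percentage points lower from compound 2 to compound 3 (within the scatter).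

Compound 4 `CCCCCCc1ccc(S(=O)(=O)Nc2cccc(-c3csc(NC(C)=O)n3)c2)cc1` is not yet measured. It differs from compound 3 by hydrogen in place of ethyl on a saturated chain carbon, six bonds along the chain from an aromatic carbon. Compound 1 differs from compound 2 by hydrogen in place of ethyl on a saturated chain carbon, six bonds along the chain from a triple-bonded carbon, the same kind of change, although there the place lies six bonds along the chain from a triple-bonded carbon rather than from an aromatic carbon. The cores of compound 2 and compound 3 differ by octyl in place of dec-1-yn-1-yl on an aromatic carbon. That earlier step was a number 1.1 percentage points higher from compound 2 to compound 1 (within the scatter), well within the scatter. A step of similar size is expected here, a number 3.2 percentage points higher from compound 3 to compound 4 (within the scatter), because of a number 1.1 percentage points higher from compound 2 to compound 1 (within the scatter). On that basis compound 4 is estimated at 38%, between 27% and 50%.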

Compound 4, a percentage reported as activity, at one concentration (the size of the read-out at that concentration, not a potency): 49.9%
Beside the measured number, compound 4's estimate is 11.9 percentage points below it; the range from low to high includes it.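

In this assay, hydrogen in place of ethyl on the saturated chain gives a number 15.1 percentage points higher from compound 3 to compound 4 (beyond the scatter), and the same change on the chain with a triple bond cannot be told apart from it: the same change on two cores in this assay, a number 1.1 percentage points higher (within the scatter) from compound 2 to compound 1 and a number 15.1 percentage points higher (beyond the scatter) from compound 3 to compound 4, 14 percentage points apart, within the scatter of two such steps. This fits a change that carries over from one core to the other, but a single pair of steps cannot prove that it does, nor show that the saturated chain responds more strongly. Hexyl in place of the chains with a triple bond gives a number 10.3 percentage points higher from compound 2 to compound 4 (beyond the scatter) and a number 9.2 percentage points higher from compound 1 to compound 4 (within the scatter), so only the first of these two steps clearly separates compound 4 from its partner.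

Still open, from the compounds shown here alone, is how the read-out would follow a longer saturated chain such as decyl, or an amine or a carboxylic acid in place of the chain. With only one concentration tested, these numbers speak only of a stronger or weaker effect at that concentration.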